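Anilide variation on a shared tricyclic-sugar core

This account rests on a few compounds, and the source may have more. Where it says the series, first, only, none or still open, it means among the compounds named here.

Measured so far:
- compound 1, `CCCc1ccc(NC2=CC(=O)c3nc4n(c3C2=O)[C@H]2OC[C@@H](O)[C@H]2OC4)cc1`: in a functional assay on MCF7 cells (Homo sapiens) for inhibition, read by sulforhodamine B assay (on this read-out lower numbers stand for stronger inhibition and higher numbers for weaker inhibition), compound 1 gives 4660 nM.
- compound 2, `O=C1C(Nc2ccc(C(F)(F)F)cc2)=CC(=O)c2c1nc1n2[C@H]2OC[C@@H](O)[C@H]2OC1`: in this assay compound 2 gives only a limit, > 4000 nM.

Among the compounds with values here, compound 1 carries the single real number in this set; the other result is a limit, as the limit of > 4000 nM in this assay, at which 1 of the 2 values shown sits, records, so no measured step between two compounds exists here and nothing can be said about how large a change in the aryl substituent moves the read-out.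

Compound 3, `COc1ccc(NC2=CC(=O)c3nc4n(c3C2=O)[C@H]2OC[C@@H](O)[C@H]2OC4)cc1`, is the next point. It differs from compound 1 by methoxy in place of propyl on an aromatic carbon. The swap keeps the ring and its substitution pattern and changes only the group para to the large group.

Within the data shown here, with no measured step to lean on, the expectation is cautious: compound 3 is expected to sit close to compound 1, with a step of a 1.0-fold lower number from compound 1 to compound 3 (0.02 log units; within the scatter) that stays within the scatter rather than beyond it. Compound 3 is estimated at 4500 nM, with a range from 1500 nM to 13000 nM, and a real chance that the result comes back as a limit instead of a number.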

Compound 3, half-maximal inhibitory concentration: 5420 nM
Estimate against measurement, compound 3: 1.2-fold (0.08 log units) below, and the stated range covers the measured number.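

The series now holds its first measured step in this assay, for methoxy in place of propyl on an aromatic carbon, para to a large group: a 1.2-fold higher number from compound 1 to compound 3 (0.07 log units; within the scatter). At this place, 4-propylphenyl and 4-methoxyphenyl therefore read alike, even though the swap exchanges an all-carbon chain with no hydrogen-bond acceptor for a group that has one. Compound 2 gives only a limit, so steps to or from it cannot be read and it adds no size of effect at this position: the limit of > 4000 nM in this assay, at which 1 of the 3 values shown sits.

On these data alone, whether any group at this place can move the number beyond the scatter stays open, and one step within the scatter does not predict the outcome for a primary amine, a carboxylic acid or a longer chain such as hexyl on the same ring. Also open, as far as these compounds go, is what a change away from this ring, for example at the free hydroxyl of the shared core, would do to the read-out in this assay.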